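Swapping bromine for fluorine on a hydrazone side chain

The source may hold more compounds than are shown below. What is called first, only, known or untested is meant among the compounds shown, and "the series" means these compounds.

Measured so far in an ADME assay on HEL cells (Homo sapiens) for cytotoxicity; a higher number here means that more compound is tolerated, a lower number that less compound is tolerated:
Compound 1, `O=C(COc1cccc2ccccc12)N/N=C/c1ccc(Br)cc1`, gives > 100 ug/mL, a limit of the assay.
Compound 2, `C/C(=N\NC(=O)COc1cccc2ccccc12)c1ccc(Cl)cc1`, gives >= 4 ug/mL, also a limit of the assay.

Compound 1 therefore stands only at a limit in this assay: the value recorded for it is the limit of > 100 ug/mL in this assay, at which 1 of the 2 values shown sits, so no number is known for it. Compound 2 likewise sits at a limit, (the limit of >= 4 ug/mL in this assay, at which 1 of the 2 values shown sits). For the measured compounds named here, with both values being limits and no step between measured compounds available, nothing more can be read from the pair than that each is a limit.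

Compound 3, `O=C(COc1cccc2ccccc12)N/N=C/c1ccc(F)cc1`, has not yet been measured. It differs from compound 1 by fluoro in place of bromo on an aromatic carbon. One halogen replaces another on the aromatic carbon, para to a large group, with no change in rings, hydrogen-bond donors or acceptors, or charge. Going by the values given here, no measured step speaks to this change, so the expected step in this assay is none beyond the scatter, a number no higher from compound 1 to compound 3 (the limit leaves the size open). Compound 3 is accordingly expected to give about 100 ug/mL in this assay, in the range 50 ug/mL to 200 ug/mL, most likely reported again as a limit.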

Compound 3, minimum cytotoxic concentration: 100 ug/mL
Compound 3: the middle estimate sits on the measured number at the digits printed; low and high end bracket the measured number.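

In this assay, for the compounds shown here, compound 3 gives 100 ug/mL, the first value in this short series that is an actual number rather than a limit. It gives the 4-fluorophenyl compound a fixed reference point, and replacing the bromo with fluoro on this aromatic carbon, para to a large group, is now a readable comparison in one direction only: a number no higher from compound 1 to compound 3 (the limit leaves the size open). Compound 1 still stands only at a limit, so the real distance between the two halogen compounds stays unknown: the limit of > 100 ug/mL in this assay, at which 1 of the 3 values shown sits.

The compounds shown leave open how the tolerated concentration would respond to a group other than a halogen at this same place, such as an amine, a carboxylic acid or a nitrile. They also leave open what a chloro alone would do here, as compound 2 differs from compound 1 in more than one place and cannot be compared with it.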